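This account rests on a few compounds, and the source may have more. Where it says the series, first, only, none or still open, it means among the compounds named here.

Measured so far in a functional assay on DU-145 cells (Homo sapiens) for inhibition, read by MTT assay, with a stated time of 48 h; a lower number here means a stronger inhibitor, a higher number a weaker inhibitor
Compound 1 (`CCc1ccc(-c2nc3ccccn3c2Sc2ccccc2)cc1`) gives 84500 nM
Compound 2 (`c1ccc(Sc2c(-c3cccc4ccccc34)nc3ccccn23)cc1`) gives 60600 nM
Compound 3 (`c1ccc(Sc2c(-c3ccccc3)nc3ccc(-c4ccccc4)cn23)cc1`) gives 71700 nM

Compound 1 stands level with compound 2 and compound 3. All three numbers lie within the usual scatter of one another, so they cannot be ranked.

Compound 4 (`N#Cc1ccc(-c2nc3ccccn3c2Sc2ccccc2)cc1`) has not yet been measured. It differs from compound 1 in one place, with cyano in place of ethyl on an aromatic carbon, turning 4-ethylphenyl into 4-cyanophenyl (cyano in place of ethyl on an aromatic carbon).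

For the measured compounds named here, no measured pair here differs in one place only, so this change has no direct precedent. The expectation rests instead on compound 2 at 60600 nM and compound 3 at 71700 nM in this set, as both differ structurally from compound 1 yet remain within the scatter of it. No step beyond the scatter is therefore expected in this assay for this change. The expected step is a 1.4-fold lower number from compound 1 to compound 4 (0.15 log units; within the scatter) and would be too small to read as a real direction. For compound 4 the estimate is 60000 nM with an expected range from 25000 nM to 120000 nM for repeat measurements.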

Compound 4, half-maximal inhibitory concentration: 76500 nM
Estimate against measurement, compound 4: 1.3-fold (0.11 log units) below; the measured number falls inside the stated range.
By their numbers in this assay, from the lowest: compounds 2, 3, 4 and 1 (each within the scatter of the next).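

Turning 4-ethylphenyl into 4-cyanophenyl is the first change in this set made in one place only, and in this assay it gives a 1.1-fold lower number from compound 1 to compound 4 (0.04 log units; within the scatter). At this position, para to a large group, cyano brings a triple bond and a hydrogen-bond acceptor that ethyl lacks, yet the numbers of the two compounds cannot be told apart. Nothing available here offers an explanation for this result.

On these data alone, it remains open whether any group at this position can shift the number beyond the scatter; an amine, a carboxylic acid or a longer chain placed there would test that. A single pair also leaves open whether the same swap would read the same way on the core of compound 3.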